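The source may report more compounds than this note shows. Statements on the series, on what has been measured and on what is new or still open speak of the compounds shown alone.

Measured so far:
Compound 1 `O=C(/C=C/c1ccccc1)NNC(=O)c1ccccc1O` gives 39300 nM in a functional assay on HL-60 cells (Homo sapiens) for cytotoxicity, read by MTT assay, with a stated time of 72 h; a higher number here means a weaker inhibitor, a lower number a stronger inhibitor.
Compound 2 `COCOc1cc(/C=C/C(=O)OCC(=O)Nc2ccc(OC)cc2)ccc1OCc1ccccc1` reaches only a limit, > 200000 nM, in this assay.

Compound 2 thus stands at the limit of > 200000 nM in this assay, at which 1 of the 2 values shown sits, so its value is a limit of the measurement and not a number. Compound 3 `COCOc1cc(/C=C/C(=O)OCC(=O)Nc2ccc(Cl)cc2)ccc1OCc1ccccc1` differs from it by one change: chloro in place of methoxy on an aromatic carbon. For the measured compounds named here, no step between two measured compounds is known, so the expected step in this assay is none beyond the usual scatter. Compound 3 is therefore expected to give 250000 nM, most likely between 80000 nM and 800000 nM. The expected step is a step that the limit leaves unreadable from compound 2 to compound 3.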

Compound 3, half-maximal inhibitory concentration: > 200000 nM
Compound 3: a limit, no number; the forecaster's own chance of this, stated with the estimate: 75%; the middle value does not contradict the limit.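

In this assay, for the compounds shown here, compound 3 gives > 200000 nM, a limit and not a number, just as compound 2 does, so no step between them can be read. As far as these compounds go, whether chloro in place of methoxy changes the activity at all stays open.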